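Bromo at the aryl ring: substituent step on compound 1

The compounds below may be only part of what the source reports. "The series", "measured", "known", "first", "only" and "open" are said of these compounds alone.

Working notes on the series. The shared core of compound 1 `COc1cc(/C=N/Nc2nc(-c3ccccc3)cs2)cc(Br)c1OC` carries a phenyl group; in a functional assay on U-87MG ATCC cells for inhibition, with U-87 MG (Homo sapiens) as the target, read by MTT assay, with a stated time of 48 h (on this read-out lower numbers stand for stronger inhibition and higher numbers for weaker inhibition), compound 1 gives 74100 nM, the highest of the two numbers recorded, with compound 3 `COc1cc(/C=N/Nc2nc(-c3ccc(C(F)(F)F)cc3)cs2)cc(Br)c1OC` nearest at 41000 nM. Compound 2 `Fc1ccc(/C=N/Nc2nc(-c3ccc(Br)cc3)cs2)cc1F` returns only a limit of the assay, > 100000 nM. Among the measured compounds shown here, the one step that can be read within this set is a 1.8-fold lower number from compound 1 to compound 3 (0.26 log units; within the scatter).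

The step to compound 4 `COc1cc(/C=N/Nc2nc(-c3cccc(Br)c3)cs2)cc(Br)c1OC` is bromo in place of hydrogen on an aromatic carbon. For the measured compounds named here, no measured pair shows bromo entering for hydrogen on this ring; the only substituent step on the same aromatic carbon region, trifluoromethyl in place of hydrogen, stayed within the scatter, and the set offers nothing else that bears on a bromo entry. The only further point of reference is the limit of > 100000 nM in this assay, at which 1 of the 3 values shown sits, which says nothing about the direction of a step from compound 1.

On that basis no change beyond the scatter is expected from compound 1 to compound 4 in this assay, the expected step being a 1.2-fold lower number from compound 1 to compound 4 (0.09 log units; within the scatter). Compound 4 is therefore estimated at 60000 nM, with a range from 25000 nM to 150000 nM, and there is a real chance that the read-out comes back as a limit rather than a number.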

Compound 4, half-maximal inhibitory concentration: 86300 nM
Compound 4: middle estimate off by 1.4-fold (0.16 log units), on the low side; the range from low to high includes it.
By their numbers in this assay, from the lowest: compounds 3, 1 and 4 (each within the scatter of the next, the first and the last beyond it). At a limit, above all of these: compound 2.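

In this assay, 3-bromophenyl in place of phenyl gives a 1.2-fold higher number from compound 1 to compound 4 (0.07 log units; within the scatter), so on this evidence a bromo on an aromatic carbon, meta to a large group, does not move the read-out away from that of compound 1. Alongside the trifluoromethyl step, a 1.8-fold lower number from compound 1 to compound 3 (0.26 log units; within the scatter), this makes two substituent entries on this six-membered aromatic ring of carbon only, and neither step leaves the scatter. Compound 2 differs from compound 1 in more than one place and holds the only limit in the set, so it adds nothing to the reading of this position: the limit of > 100000 nM in this assay, at which 1 of the 4 values shown sits.

Open, from the compounds shown here alone, is whether any group on this ring can move the number beyond the scatter, since a bromo and a trifluoromethyl say little about what an amine, a carboxylic acid or a longer chain would do on the same carbon. Also open is how much of the read-out depends on the bromo of the shared core, since no single-place step among the compounds shown touches that group.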